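Cytotoxicity notes on a hydrazone series, compound 3 to compound 4

This account rests on a few compounds, and the source may have more. Where it says the series, first, only, none or still open, it means among the compounds named here.

Measured compounds:
- compound 1 `CN(C)CCn1cnnc1-c1cc(Oc2ccc(NC(=O)N/N=C/c3ccc(O)c(F)c3)cc2F)ccn1`: in an ADME assay on WI-38 cells (Homo sapiens) for cytotoxicity, read by MTT assay, with a stated time of 72 h (a lower number here means a stronger inhibitor, a higher number a weaker inhibitor), compound 1 gives "not determined" (no result reported)
- compound 2 `CN(C)CCn1cnnc1-c1cc(Oc2ccc(NC(=O)N/N=C/c3ccc(O)cc3)cc2F)ccn1`: in this assay compound 2 gives "not determined" (no result reported)
- compound 3 `CN(C)CCn1cnnc1-c1cc(Oc2ccc(NC(=O)N/N=C/c3ccc(O)c(Br)c3)cc2F)ccn1`: 5560 nM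

Three compounds of the series share one core and differ only in the group on a carbon with a double bond to nitrogen. In this assay compound 1 gives "not determined" (no result reported) and compound 2 gives "not determined" (no result reported); no number is available for either. Among the measured compounds shown here, compound 3 is therefore the only compound with a value: in this assay compound 3 gives 5560 nM. For the measured compounds named here, with a single number there is no step between measured compounds to compare, and no ranking of compound 3 within the series is possible.

Compound 4 `CN(C)CCn1cnnc1-c1cc(Oc2ccc(NC(=O)N/N=C/c3c(O)ccc4ccccc34)cc2F)ccn1` is the next compound to be run in this assay. Its change from compound 3 is 2-hydroxynaphthalen-1-yl in place of 3-bromo-4-hydroxyphenyl on a carbon with a double bond to nitrogen. The hydroxyl and the counts of hydrogen-bond donor and acceptor are unchanged; what enters is a second six-membered aromatic ring of carbon only in place of the bromine.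

Going by the values given here, no step is available to set a size for this change. The expectation for compound 4 is a step from compound 3 of a 1.1-fold lower number from compound 3 to compound 4 (0.05 log units; within the scatter), that is, none beyond the scatter in either direction. For compound 4 the estimate in this assay is 5000 nM, with a range from 1800 nM to 14000 nM.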

Compound 4, half-maximal inhibitory concentration: 3250 nM
For compound 4 the middle estimate is 1.5-fold (0.19 log units) above the measured one; the measured number falls inside the stated range.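

In this assay, 2-hydroxynaphthalen-1-yl in place of 3-bromo-4-hydroxyphenyl on a carbon with a double bond to nitrogen gives a 1.7-fold lower number from compound 3 to compound 4 (0.23 log units; within the scatter). Among the compounds shown here, this is the first step that can be read at this position, and it shows that a single change can remove the bromine and add a second six-membered aromatic ring of carbon only without moving the number beyond the scatter; the two parts of that change cannot be separated from this one step. No measured evidence bearing on this result is available, and no cause can be assigned to it.

Steps involving compound 1 or compound 2 cannot be read, so the 3-fluoro-4-hydroxyphenyl and 4-hydroxyphenyl groups give no comparison with compound 3 or compound 4. Still open, on these data alone, is whether a different kind of group on this carbon, such as a phenyl ring carrying an amine or a carboxylic acid, would give a step beyond the scatter from compound 3 or compound 4.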